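The compounds below may be only part of what the source reports. "The series", "measured", "known", "first", "only" and "open" are said of these compounds alone.

Measured compounds: compound 1 `CSc1cnc2ccccc2c1SCC#CCOC(=O)c1ccccc1` with 17.8 ug/mL in a functional assay on B16 cells (Mus musculus) for antiproliferative activity, with a stated time of 72 h (a higher number here means a weaker inhibitor, a lower number a stronger inhibitor), and compound 2 `CSc1cnc2ccccc2c1SCC#CCOC(=O)c1ccc(C(=O)O)cc1` with 18.1 ug/mL in the same assay.

Among the measured compounds shown here, compound 2 stands together with compound 1: its number in this assay and that of compound 1 lie within the usual scatter of each other, as the one measured step shows, a 1.0-fold higher number from compound 1 to compound 2 (0.01 log units; within the scatter).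

Compound 3 `CSc1cnc2ccccc2c1SCC#CCOC(=O)/C=C/c1ccccc1` has not been measured. It differs from compound 2 in one place: 2-phenylethenyl in place of 4-carboxyphenyl on a carbonyl carbon. For the measured compounds named here, the only measured step, which swapped carboxy for hydrogen on an aromatic carbon in the same part of the molecule, was flat. The new change is larger, since it replaces the whole 4-carboxyphenyl with 2-phenylethenyl, so that step bears on it only partly. No step beyond the scatter is expected; compound 3 is estimated at 18 ug/mL, within 8 ug/mL to 40 ug/mL, a step of a 1.0-fold lower number from compound 2 to compound 3 (0.00 log units; within the scatter).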

Compound 3, concentration for 50% inhibition: 9.4 ug/mL
Compound 3: the middle estimate sits 1.9-fold (0.28 log units) above what was measured; measured number inside the range.
By their numbers in this assay, from the lowest: compounds 3, 1 and 2 (each within the scatter of the next).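

On a carbonyl carbon whose other neighbours are oxygen next to a carbonyl group, the earlier pair showed only a change on the aromatic ring, whereas this result replaces the whole group: in this assay, putting 2-phenylethenyl in place of 4-carboxyphenyl gives a 1.9-fold lower number from compound 2 to compound 3 (0.28 log units; within the scatter). Putting 2-phenylethenyl in place of phenyl gives a 1.9-fold lower number from compound 1 to compound 3 (0.28 log units; within the scatter), so phenyl, 4-carboxyphenyl and 2-phenylethenyl cannot be told apart here, even though the 2-phenylethenyl group adds a double bond outside the ring and carries no hydrogen-bond donor or acceptor. Nothing available explains why these numbers lie so close together.

From the compounds shown here alone, whether a group of another kind on this carbonyl carbon, such as an amine or a longer saturated carbon chain, would move the number beyond the scatter remains open. The compounds shown also leave open whether changes elsewhere in the molecule, on the shared core or in the chain holding the triple bond, matter more than this position does.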